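Methoxy to Hydroxy: Expecting Compound 4

A few compounds are considered here, and "the series" means these few. Any claim that something is new, unique, unknown or untested is made for them only; others in the source may bear on it.

Compound 1, `COc1cc(C)cc(-c2nn(CC#N)cc2-c2ccc(-c3cccc(C(C)=O)c3)nc2)c1`, in a functional assay on NCI/ADR-RES cells (Homo sapiens) for cytotoxicity, read by sulforhodamine B assay, with a stated time of 48 h, tested at 10 uM (a lower number here means a stronger effect, a higher number a weaker effect of the compound at the concentration tested), gives -14%.
Compound 2, `Cc1cc(O)cc(-c2nn(CC#N)cc2-c2ccnc(-c3ccc(Oc4ccccc4)cc3)c2)c1`, in this assay gives -52%.
Compound 3, `COc1cc(C)cc(-c2nn(CC#N)cc2-c2ccnc(-c3ccc(N(C)C)cc3)c2)c1`, in this assay gives -10%.

Among the three measured compounds, compound 3 shows the highest number, which here means the weakest effect. Its nearest neighbour is compound 1, whose number lies within the usual scatter, so the two cannot be ranked against each other. Compound 2 sits far below both, beyond the scatter.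

Compound 4, `Cc1cc(O)cc(-c2nn(CC#N)cc2-c2ccnc(-c3ccc(N(C)C)cc3)c2)c1`, has not yet been tested in this assay. It differs from compound 3 in a single spot: hydrogen in place of methyl on an oxygen on an aromatic ring. Compound 2 also carries a hydroxy group and gives -52%, the lowest number of the set, but it differs from compound 3 in more than one place, so that comparison cannot be pinned on the hydroxy group alone. Within the data shown here, no measured pair shows this one change by itself. The step is therefore expected to be modest and downward, possibly not beyond the scatter: a number 10 percentage points lower from compound 3 to compound 4 (within the scatter). Compound 4 is expected to give about -20%, within a range from -48% to 5%.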

Compound 4, a percentage reported as activity, at one concentration (the size of the read-out at that concentration, not a potency): -4%
Beside the measured number, compound 4's estimate is 16 percentage points below it, within the range that was stated.
By their numbers in this assay, from the lowest: compound 2; then compounds 1, 3 and 4 (each within the scatter of the next).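

Within this assay the change from methoxy to hydroxy gives a number 6 percentage points higher from compound 3 to compound 4 (within the scatter) and so, with dimethylamino on the other side of the molecule, this swap alone does not shift the number measurably. The pair that keeps the hydroxy group and changes only the far substituent tells a different story: dimethylamino in place of phenoxy gives a number 48 percentage points higher from compound 2 to compound 4 (beyond the scatter) and shows that a hydroxy group does not by itself bring a number as low as that of compound 2.

Still open, from the compounds shown here alone, is whether methoxy to hydroxy stays this small when phenoxy is present, and whether an ethoxy group or an amine on the oxygen-bearing spot of the aromatic ring would move the number beyond the scatter. What lies behind either step cannot be said from the information at hand.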